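Methyl to Ethyl on Two Related Cores

The compounds below may be only part of what the source reports. "The series", "measured", "known", "first", "only" and "open" are said of these compounds alone.

Measured compounds:
compound 1 `Cn1nc(-c2ccnc(Nc3ccc(S(N)(=O)=O)cc3)n2)c2ccccc21` gives 940 nM
compound 2 `CCn1nc(-c2ccnc(Nc3ccc(S(N)(=O)=O)cc3)n2)c2ccccc21` gives 2280 nM
compound 3 `Cc1nn(-c2ccnc(Nc3ccc(S(N)(=O)=O)cc3)n2)c2ncccc12` gives 8640 nM

All three were tested in a functional assay on MCF7 cells (Homo sapiens) for antiproliferative activity, read by MTT assay, with a stated time of 72 h; a lower number here means a stronger inhibitor of growth, a higher number a weaker inhibitor of growth. Compound 1 and compound 2 share one core and differ by methyl in place of hydrogen on a saturated chain carbon bound to an aromatic nitrogen. That change produced a 2.4-fold higher number from compound 1 to compound 2 (0.38 log units; beyond the scatter), so the longer chain on this core weakened growth inhibition by a modest but real amount.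

Compound 3 sits on a different core, and the difference between the two cores is not broken down here. In this assay compound 3 gives the highest number of the three, well beyond the scatter from both compound 2 and compound 1.

Compound 4 `CCc1nn(-c2ccnc(Nc3ccc(S(N)(=O)=O)cc3)n2)c2ncccc12` has not yet been measured. It differs from compound 3 by methyl in place of hydrogen on a saturated chain carbon bound to an aromatic carbon. This is the same kind of change as that from compound 1 to compound 2, but not the same: in the first pair the saturated chain carbon is bound to an aromatic nitrogen, whereas in compound 4 it is bound to an aromatic carbon, so the surroundings of the change are not identical.

Going by the values given here, with only one measured example of this change, the expectation for compound 4 rests on the step from compound 1 to compound 2 and on the value of compound 3. Compound 4 is expected to show a 2.0-fold higher number from compound 3 to compound 4 (0.29 log units; within the scatter), a step of similar size and direction, starting from the weaker compound 3. Compound 4 is therefore estimated at 17000 nM, with a likely range from 6500 nM to 45000 nM.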

Compound 4, concentration for 50% growth inhibition: 880 nM
For compound 4 the middle estimate is 19-fold (1.29 log units) above the measured one, outside the stated range (below it).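

On the core of compound 3, the change gave a 9.8-fold lower number from compound 3 to compound 4 (0.99 log units; beyond the scatter) in this assay, so on this core the longer chain strengthened growth inhibition instead of weakening it. Set beside the earlier pair, the step differs in direction as well as in size, which means that the effect of this change cannot simply be carried from one core to the other in this series: the same change on two cores in this assay, a 2.4-fold higher number (0.38 log units; beyond the scatter) from compound 1 to compound 2 and a 9.8-fold lower number (0.99 log units; beyond the scatter) from compound 3 to compound 4, 24-fold (1.38 log units) apart, beyond the scatter of two such steps What this does not show is the reason for the reversal, since the two pairs differ both in their cores and in whether the saturated chain carbon is bound to an aromatic nitrogen or an aromatic carbon, and a single pair of each kind cannot separate those two differences or say how the change would behave on a further core.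

The compounds shown leave open whether a longer chain, such as propyl, would extend the gain seen on the core of compound 3 or the loss seen on the core of compound 1. They also leave open how a cyclopropyl group or an amine in the same place would behave on either core.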